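The compounds below may be only part of what the source reports. "The series", "measured", "known", "first", "only" and "open" are said of these compounds alone.

Compound 2 `CC1(C)Cc2c(sc(NC(=O)C3(CO)CC3)c2C(N)=O)C(C)(C)O1` gives 15 nM in an assay on cells for positive allosteric modulation of Cystic fibrosis transmembrane conductance regulator variant F508del (Homo sapiens), with stated times of 10 min and 7 s, in the presence of a further agent that is not named here (a higher number here means that more compound is needed for the effect, a lower number that less compound is needed), the only number shown among the two measured compounds. Compound 1 `CC1(C)Cc2c(sc(NC(=O)C3CNC(=O)C3)c2C(N)=O)C(C)(C)O1` reaches only a limit of this assay, > 10000 nM. For the measured compounds named here, the one measured step, an at least 660-fold lower number from compound 1 to compound 2 (2.82 log units; beyond the scatter), therefore rests on a limit (the limit of > 10000 nM in this assay, at which 1 of the 2 values shown sits). Compound 3 `CC1(C)Cc2c(sc(NC(=O)C(C)(C)CO)c2C(N)=O)C(C)(C)O1` differs from compound 2 by 1-(hydroxymethyl)-1-methylethyl in place of 1-(hydroxymethyl)cyclopropyl on a carbonyl carbon. That measured step exchanged a wholly different group, so it bears little on opening a small ring into a branched chain. For compound 3 the expected value in this assay is 30 nM, with a range from 8 nM to 120 nM. The expected step of a 2.0-fold higher number from compound 2 to compound 3 (0.30 log units; within the scatter) is estimated to stay within the scatter.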

Compound 3, half-maximal effective concentration: 75 nM
Estimate against measurement, compound 3: 2.5-fold (0.40 log units) below; low and high end bracket the measured number.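

With the same count of heavy atoms on the carbonyl carbon, opening the three-membered ring into 1-(hydroxymethyl)-1-methylethyl gives a 5.0-fold higher number from compound 2 to compound 3 (0.70 log units; beyond the scatter) in this assay, so this position responds to the ring, though only modestly. The ring is not needed for most of the gain, as the open chain still gives an at least 130-fold lower number from compound 1 to compound 3 (2.12 log units; beyond the scatter). That step rests on a limit, the one reached by compound 1: the limit of > 10000 nM in this assay, at which 1 of the 3 values shown sits.

The compounds shown leave open whether the hydroxyl matters, as an amine or a plain methyl in its place would test. Also open, as far as these compounds go, is how a cyclobutyl ring would compare.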